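The source may hold more compounds than are shown below. What is called first, only, known or untested is meant among the compounds shown, and "the series" means these compounds.

Measured in a functional assay on MDA-MB-231 cells (Homo sapiens) for antiproliferative activity, read by sulforhodamine B assay, with a stated time of 72 h; a lower number here means a stronger inhibitor, a higher number a weaker inhibitor:
- compound 1 `FC(F)(F)c1ccc(/C=C\c2cc3ccc(Cl)cc3nc2Cl)cc1` gives 13600 nM
- compound 2 `FC(F)(F)c1cccc(/C=C\c2cc3ccccc3nc2Cl)c1` gives 3750 nM
- compound 3 `FC(F)(F)c1cccc(/C=C/c2cc3ccccc3nc2Cl)c1` gives 45000 nM

Compound 2 holds the lowest number of the three, with compound 1 and compound 3 both higher beyond the scatter. Compound 4 `COc1ccc2nc(Cl)c(/C=C\c3cccc(C(F)(F)F)c3)cc2c1` is compound 2 with methoxy in place of hydrogen on an aromatic carbon. For the measured compounds named here, the one measured single-place step is large, a 12-fold higher number from compound 2 to compound 3 (1.08 log units; beyond the scatter), and comes with the fact that compounds 2 and 3 differ only in the configuration as drawn. Compound 4 keeps the double bond as drawn in compound 2, so this step sets no size for the methoxy change. Going by the values given here, no measured step adds a group to the shared core. Among the compounds with values here, the only weak guide has a core substituent and differs from compound 2 in a second place as well, and that guide is compound 1, which gives 13600 nM. A small rise in the number in this assay is therefore expected, with the expected step being a 1.3-fold higher number from compound 2 to compound 4 (0.12 log units; within the scatter). The estimate for compound 4 is 5000 nM, with an expected range of 1500 nM to 18000 nM.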

Compound 4, half-maximal inhibitory concentration: 3280 nM
Estimate against measurement, compound 4: 1.5-fold (0.18 log units) above; the range from low to high includes it.
By their numbers in this assay, from the lowest: compounds 4 and 2 (each within the scatter of the next); then compound 1; then compound 3.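

In this assay, for the compounds shown here, the new compound gives the first single-place step on the shared core, with methoxy in place of hydrogen on an aromatic carbon: a 1.1-fold lower number from compound 2 to compound 4 (0.06 log units; within the scatter). The earlier step concerned only the configuration of the double bond, so it said nothing about a substituent at this carbon, which is now seen to accept methoxy with no change beyond the scatter. Nothing available bears on why this replacement leaves the number within the scatter.

On these data alone, whether this carbon is as permissive for other groups, such as an amine, a carboxylic acid or a longer alkoxy chain, remains open. Also open, as far as these compounds go, is whether methoxy behaves the same way with the double bond drawn as in compound 3.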